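Ethylsulfanyl to Propyl: Expected Potency of Compound 4

A few compounds are considered here, and "the series" means these few. Any claim that something is new, unique, unknown or untested is made for them only; others in the source may bear on it.

Measured compounds in a functional assay on Jurkat cells (Homo sapiens) for activation, with a stated time of 24 h; a higher number here means that more compound is needed for the effect, a lower number that less compound is needed:
Compound 1, `Oc1ccccc1CNc1ccc(-c2ccc(-c3ccccc3)cc2)cc1`: "not active" (no number reported)
Compound 2, `COc1ccc(-c2ccc(NCc3ccccc3O)cc2)cc1`: 580 nM
Compound 3, `CCSc1ccc(-c2ccc(NCc3ccccc3O)cc2)cc1`: 1980 nM

Among the compounds with values here, compound 3 holds the highest of the two numbers seen in this assay; its nearest neighbour is compound 2, and the only single-point step on record, a 3.4-fold higher number from compound 2 to compound 3 (0.53 log units; beyond the scatter), separates them. Compound 1 gave no number at all.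

Compound 4, `CCCc1ccc(-c2ccc(NCc3ccccc3O)cc2)cc1`, differs from compound 3 by propyl in place of ethylsulfanyl on an aromatic carbon. Within the data shown here, no measured step shows this exact exchange. Among the measured compounds shown here, the one step that bears on it, a 3.4-fold higher number from compound 2 to compound 3 (0.53 log units; beyond the scatter), shows that a change at this position can move the number beyond the scatter. Compound 4 is therefore expected to land near compound 3 or somewhat weaker, with the estimated step of a 1.3-fold higher number from compound 3 to compound 4 (0.12 log units; within the scatter). The estimate for compound 4 in this assay is 2600 nM, with a range from 900 nM to 7500 nM.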

Compound 4, half-maximal effective concentration: 2390 nM
Compound 4: middle estimate off by 1.1-fold (0.04 log units), on the high side; the range from low to high includes it.
By their numbers in this assay, from the lowest: compound 2; then compounds 3 and 4 (each within the scatter of the next).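

In this assay, propyl in place of ethylsulfanyl keeps the count of heavy atoms, loses the sulfur and the hydrogen-bond acceptor, and gives a 1.2-fold higher number from compound 3 to compound 4 (0.08 log units; within the scatter) so at this position the sulfur is not needed to keep the number where it stands. Methoxy remains apart from both groups, since the exchange for propyl gives a 4.1-fold higher number from compound 2 to compound 4 (0.61 log units; beyond the scatter) and matches the earlier gap to ethylsulfanyl. No measurement on hand explains this difference.

On these data alone, it remains open whether a shorter chain such as methyl, or an amine or a carboxylic acid, would fall with methoxy or with propyl at this position.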